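The compounds below may be only part of what the source reports. "The series", "measured", "known", "first", "only" and "open" are said of these compounds alone.

Compound 1 `O=C1c2c[n+]([O-])c3ccccc3c2C(=O)c2[nH]c3ccccc3c21`: 660 nM
Compound 2 `CC1(C)OCC(Cn2cc(Cn3c4c(c5ccccc53)C(=O)c3c[n+]([O-])c5ccccc5c3C4=O)nn2)O1`: 330 nM
Compound 3 `O=C1c2c[n+]([O-])c3ccccc3c2C(=O)c2c1c1ccccc1n2Cc1cn([C@H]2O[C@H](CO)[C@@H](O)[C@H]2O)nn1`: 340 nM

These numbers come from a functional assay on A-375 cells (Homo sapiens) for cytotoxicity, read by MTT assay, with a stated time of 72 h; a lower number here means a stronger inhibitor, a higher number a weaker inhibitor. Compound 1 has the highest of the three, yet its gaps to compound 3 and to compound 2 both fall within the scatter, so no order among them can be claimed. Compound 4 `CN1CCN(CCCCn2c3c(c4ccccc42)C(=O)c2c[n+]([O-])c4ccccc4c2C3=O)CC1` has not been measured; it differs from compound 1 by 4-(4-methylpiperazin-1-yl)butyl in place of hydrogen on an aromatic nitrogen. Among the measured compounds shown here, no measured step replaces hydrogen on that nitrogen. For the measured compounds named here, compound 2 and compound 3 carry other groups on the same nitrogen and sit close to compound 1, and the only measured step, a 1.0-fold higher number from compound 2 to compound 3 (0.01 log units; within the scatter), swaps one such group for another without leaving the scatter. Little change beyond the scatter is therefore expected, perhaps a slightly lower number; the expected step is a 1.6-fold lower number from compound 1 to compound 4 (0.20 log units; within the scatter). Compound 4 is expected to give 420 nM, with a range of 150 nM to 1200 nM.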

Compound 4, half-maximal inhibitory concentration: 30 nM
Estimate against measurement, compound 4: 14-fold (1.15 log units) above; the measured number lies below the stated range.
By their numbers in this assay, from the lowest: compound 4; then compounds 2, 3 and 1 (each within the scatter of the next).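

In this assay, this aromatic nitrogen proves able to shift the number strongly: 4-(4-methylpiperazin-1-yl)butyl gives a 22-fold lower number from compound 1 to compound 4 (1.34 log units; beyond the scatter), a large step beyond the scatter. Substitution here is not enough on its own, since compound 2 and compound 3 carry other groups on the same nitrogen and stay within the scatter of compound 1. Nothing shown explains the step. On these data alone, whether the ring or the chain matters more stays open. A shorter propyl chain bearing the same ring, or a butyl chain ending in morpholine or dimethylamine, could separate the two.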